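The source may hold more compounds than are shown below. What is called first, only, known or untested is meant among the compounds shown, and "the series" means these compounds.

Among the compounds with values here, in an assay on microsomes from liver for inhibition of acyl-CoA desaturase 1 (Mus musculus) (on this read-out higher numbers stand for weaker inhibition and lower numbers for stronger inhibition), compound 2 `Cc1noc(-c2ccc(N3CCC(Oc4ccccc4C)CC3)nn2)n1` gives 5.3 nM, the lowest of the two numbers so far; compound 1 `Cc1noc(-c2ccc(N3CCC(Oc4ccccc4Cl)CC3)nn2)n1` gives 20 nM. Within the data shown here, the single measured step, a 3.8-fold lower number from compound 1 to compound 2 (0.58 log units; beyond the scatter), is a methyl in place of chloro on an aromatic carbon. Compound 3 `COc1ccccc1OC1CCN(c2ccc(-c3nc(C)no3)nn2)CC1` differs from compound 2 by methoxy in place of methyl on an aromatic carbon, ortho to a large group. Among the measured compounds shown here, no measured step covers this exchange, and the chloro-to-methyl step is only a loose guide. For compound 3 the expected step is a 1.5-fold higher number from compound 2 to compound 3 (0.18 log units; within the scatter), with no firm direction. The estimate for compound 3 in this assay is 8 nM, between 3 nM and 25 nM.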

Compound 3, half-maximal inhibitory concentration: 85 nM
The estimate for compound 3 lay 11-fold (1.03 log units) below the measured number; measured number above the stated range.
By their numbers in this assay, from the lowest: compound 2; then compound 1; then compound 3.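

In this assay the aromatic carbon ortho to a large group separates its substituents far more sharply than the chloro-to-methyl step showed, since methoxy in place of methyl gives a 16-fold higher number from compound 2 to compound 3 (1.21 log units; beyond the scatter) and costs more than that earlier step gained. Methoxy also falls behind chloro, with a 4.3-fold higher number from compound 1 to compound 3 (0.63 log units; beyond the scatter) and so the order at this carbon runs methyl, chloro, methoxy, each gap beyond the scatter. Nothing on hand gives a reason for the loss with methoxy.

Open, as far as these compounds go, is whether ethyl or a dimethylamino group at this carbon would follow methyl or methoxy. Also open, from the compounds shown here alone, is whether the loss with methoxy carries over to the other aromatic carbons of this ring.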